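From compound 3 to compound 4: phenyl gives way to methyl

This account rests on a few compounds, and the source may have more. Where it says the series, first, only, none or still open, it means among the compounds named here.

In an ADME assay on HaCaT cells (Homo sapiens) for cytotoxicity, read by MTT assay, with a stated time of 72 h (a lower number here means a stronger inhibitor, a higher number a weaker inhibitor), compound 3 (`CC(C)(C)C1=CC(=O)C=C(NCc2ccccc2)C1=O`) gives 21000 nM and compound 2 (`CC1=CCC[C@H]2[C@](C)(CC3=CC(=O)C=CC3=O)[C@@H](C)CC[C@]12C`) gives 37000 nM and the two lie within the scatter of each other. Compound 1 (`CCCCNC1=CC(=O)C(C[C@]2(C)[C@@H](C)CC[C@]3(C)C(C)=CCC[C@@H]23)=CC1=O`) gives > 100000 nM as a limit of the assay and not a number. Compound 4 (`CCNC1=CC(=O)C=C(C(C)(C)C)C1=O`) differs from compound 3 by methyl in place of phenyl on a saturated chain carbon bound to an amine nitrogen. Going by the values given here, the one measured step (an at least 2.7-fold lower number from compound 1 to compound 2 (0.43 log units; beyond the scatter)) is hydrogen in place of butylamino on another core and bears only loosely on this change. Only a small move toward a higher number is expected in this assay and nothing clearly beyond the scatter. The estimated step (a 1.5-fold higher number from compound 3 to compound 4 (0.18 log units; within the scatter)) stays within that scatter. Compound 4 is estimated at 32000 nM with an expected range from 12000 nM to 85000 nM in this series.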

Compound 4, half-maximal inhibitory concentration: 30000 nM
Beside the measured number, compound 4's estimate is 1.1-fold (0.03 log units) above it, and the stated range covers the measured number.
By their numbers in this assay, from the lowest: compounds 3, 4 and 2 (each within the scatter of the next). At a limit, above all of these: compound 1.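

In this assay, the first change shown at this position stays small (a 1.4-fold higher number from compound 3 to compound 4 (0.15 log units; within the scatter)). Methyl in place of phenyl on a saturated chain carbon bound to an amine nitrogen thus removes the six-membered aromatic ring without a shift that can be told from the scatter. No measurement shown accounts for the size of this step. Still open, from the compounds shown here alone, is whether a carboxylic acid, an amine or a longer chain at this place would move the number beyond the scatter. Going by these compounds, whether the same change behaves alike on the core of compound 1 also remains open.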